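A few compounds are considered here, and "the series" means these few. Any claim that something is new, unique, unknown or untested is made for them only; others in the source may bear on it.

Measured compounds:
compound 1 (`CCNC(=S)SCC1=CCOC1=O`), reported in a functional assay on HeLa cells (Homo sapiens) for antiproliferative activity, read by MTT assay, with a stated time of 72 h (on this read-out lower numbers stand for stronger inhibition and higher numbers for weaker inhibition), as "not active" (no number reported), with no number given;
compound 2 (`CC(C)NC(=S)SCC1=CCOC1=O`), 137000 nM.

Compound 2 carries the only number shown in this assay; in this assay compound 2 gives 137000 nM, and compound 1 stands beside it only as an entry without a number. Compound 3 (`O=C1OCC=C1CSC(=S)N1CCCC1`) has not been measured. It differs from compound 2 in one place: pyrrolidin-1-yl in place of isopropylamino on a thiocarbonyl carbon. Going by the values given here, no step between measured compounds is available as a guide, so the expectation rests on compound 2 alone. The expected step in this assay is a 1.4-fold lower number from compound 2 to compound 3 (0.14 log units; within the scatter), which is taken as no change beyond the usual scatter, in no particular direction. Compound 3 is therefore estimated at 100000 nM, with a range from 30000 nM to 300000 nM, and a real chance that, like compound 1, it is reported without a number.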

Compound 3, half-maximal inhibitory concentration: 2630 nM
The estimate for compound 3 lay 38-fold (1.58 log units) above the measured number; measured number outside the range, below it.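

At the thiocarbonyl carbon whose other neighbour is sulfur, putting pyrrolidin-1-yl in place of isopropylamino gives in this assay a 52-fold lower number from compound 2 to compound 3 (1.72 log units; beyond the scatter), the first step available, and it shows that the read-out responds strongly to the group at this position, which compound 2 alone, with compound 1 reported without a number, could not show. Going by these compounds alone, the single change both removes the hydrogen-bond donor of isopropylamino and brings in a five-membered non-aromatic ring, so the step belongs to the two together. No measurement offered here accounts for the size of this step.

The compounds shown leave open whether the ring or the missing amide-type hydrogen goes with the lower number, a question a diethylamino group on the same carbon would address. They also leave open how a piperidin-1-yl or morpholin-4-yl group would read.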